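Moving the pyridine nitrogen on a cyanoguanidine sulfonamide

The compounds below may be only part of what the source reports. "The series", "measured", "known", "first", "only" and "open" are said of these compounds alone.

Compound 2 `N#C/N=C(\NCc1ccc(S(=O)(=O)N2CC3CCC(C2)O3)cc1)Nc1ccncc1` gives 50 nM in a functional assay on A2780 cells (Homo sapiens) for antiproliferative activity, read by sulforhodamine B assay, with a stated time of 72 h; a higher number here means a weaker inhibitor, a lower number a stronger inhibitor. Its only measured companion, compound 1 `N#C/N=C(\NCc1ccc(S(=O)(=O)c2ccccc2)cc1)Nc1cccnc1`, gives 30 nM in this assay, and the two numbers sit within the scatter of each other, so neither can be called the stronger inhibitor. Among the measured compounds shown here, no single-change step between measured compounds is available. Compound 3 `N#C/N=C(\NCc1ccc(S(=O)(=O)N2CC3CCC(C2)O3)cc1)Nc1cccnc1` differs from compound 2 in one place: pyridin-3-yl in place of pyridin-4-yl on an amine nitrogen. The two compounds share all their atoms and differ only in how the ring nitrogen is placed. The same pyridin-3-yl group appears in compound 1, whose value gives no sign of a large effect in either direction. He therefore expects no step beyond the scatter; the expected step, a 1.4-fold lower number from compound 2 to compound 3 (0.15 log units; within the scatter), is small. Compound 3 is estimated at 35 nM, with a range from 12 nM to 100 nM.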

Compound 3, half-maximal inhibitory concentration: 175 nM
The estimate for compound 3 lay 5.0-fold (0.70 log units) below the measured number; the whole stated range lies below it.
By their numbers in this assay, from the lowest: compounds 1 and 2 (each within the scatter of the next); then compound 3.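

In this assay, the placing of the ring nitrogen alone proves to matter on this amine nitrogen: with the same atoms, pyridin-3-yl in place of pyridin-4-yl gives a 3.5-fold higher number from compound 2 to compound 3 (0.54 log units; beyond the scatter). With pyridin-3-yl held fixed, the group on the sulfonyl sulfur matters as well, since the group of 8 heavy atoms in place of the group of 6 heavy atoms gives a 5.8-fold higher number from compound 1 to compound 3 (0.77 log units; beyond the scatter), so the low number of compound 1 does not carry over to the new sulfonyl group. Nothing available here accounts for either step.

The compounds shown leave open how pyridin-2-yl or an unsubstituted phenyl ring would fare on this amine nitrogen. They also leave open whether pyridin-4-yl would pair with the group of 6 heavy atoms on the sulfonyl sulfur to give a lower number still.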